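A few compounds are considered here, and "the series" means these few. Any claim that something is new, unique, unknown or untested is made for them only; others in the source may bear on it.

Three compounds have been measured in an ADME assay on L1210 cells (Mus musculus) for inhibition, read by cell counting; on this read-out lower numbers stand for stronger inhibition and higher numbers for weaker inhibition:

Compound 1, `CSc1nc(NCCCNc2ccnc3cc(Cl)ccc23)c(C#N)c(-c2ccccc2)n1`, gives 4700 nM.
Compound 2, `CSc1nc(NCCCCNc2ccnc3cc(Cl)ccc23)c(C#N)c(-c2ccccc2)n1`, gives 4400 nM.
Compound 3, `CSc1nc(OCCCNc2ccnc3cc(Cl)ccc23)c(C#N)c(-c2ccccc2)n1`, gives 3900 nM.

Compound 2 sits among three numbers that all lie within the usual scatter of one another, so none of the three can be set apart from the others on these data. Its value is close to that of compound 1 and equally close to that of compound 3.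

Compound 4, `CSc1nc(NCCCCNc2ccnc3cc(Cl)ccc23)c(C#N)c(-c2ccc([N+](=O)[O-])cc2)n1`, keeps the whole of compound 2 and adds one group: nitro in place of hydrogen on an aromatic carbon. Among the compounds with values here, no pair of measured compounds shows what such an exchange does in this assay, and the three values available move so little across their own differences that they give no direction either way. The expectation is therefore a step of modest size, with no clear direction and most likely none beyond the scatter, so that from compound 2 to compound 4 the change is estimated at a 1.1-fold lower number from compound 2 to compound 4 (0.04 log units; within the scatter). For compound 4 the expected value is 4000 nM, within a range from 1500 nM to 10000 nM.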

Compound 4, half-maximal inhibitory concentration: 960 nM
Compound 4: middle estimate off by 4.2-fold (0.62 log units), on the high side; measured number outside the range, below it.
By their numbers in this assay, from the lowest: compound 4; then compounds 3, 2 and 1 (each within the scatter of the next).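

Putting nitro in place of hydrogen on the phenyl ring, para to a large group, gives a 4.6-fold lower number from compound 2 to compound 4 (0.66 log units; beyond the scatter) in this assay, so inhibition is stronger with the 4-nitrophenyl group. The three earlier values all lay within the scatter of one another, so this is the first change shown here that clearly moves the number, and it marks this ring position as one where a substitution can matter. Nothing measured here speaks to what lies behind the drop.

Going by these compounds, it remains open whether the effect is particular to nitro or would also appear with another group at the same place, such as an amine, a carboxylic acid or a chlorine atom. On these data alone, it is also open whether the same exchange would have a similar effect on compound 1 or compound 3.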